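Chromene acids and esters: inactive series, one new analogue

The source may report more compounds than this note shows. Statements on the series, on what has been measured and on what is new or still open speak of the compounds shown alone.

Measured compounds, as they stand:
- compound 1 `CCOC(=O)C1=Cc2ccccc2OC1(OCc1cc(-c2ccc3ccccc3c2)no1)C(F)(F)F`: > 150000 nM
- compound 2 `CCOC(=O)C1=Cc2ccccc2OC1(OCc1cn(CC(=O)Nc2ccccc2Br)nn1)C(F)(F)F`: > 150000 nM
- compound 3 `O=C(O)C1=Cc2ccccc2OC1(OCc1cc(-c2ccc3ccccc3c2)no1)C(F)(F)F`: > 150000 nM

In a functional assay on HeLa cells (Homo sapiens) for inhibition, read by MTT assay, with a stated time of 24 h (a higher number here means a weaker inhibitor, a lower number a stronger inhibitor), compound 1 gives only a limit, > 150000 nM. Compound 2 in this assay likewise gives only a limit, > 150000 nM. Compound 3 in this assay again gives only a limit, > 150000 nM. Among the compounds with values here, the one step between measured compounds, a step that the two limits leave unreadable from compound 1 to compound 3, is therefore not readable in size, and no ranking among the three can be drawn, since (the limit of > 150000 nM in this assay, at which 3 of the 3 values shown sit).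

Compound 4 `COc1ccc(-c2cc(COC3(C(F)(F)F)Oc4ccccc4C=C3C(=O)O)on2)cc1` is not yet measured. It differs from compound 3 in one place: 4-methoxyphenyl in place of naphthalen-2-yl on an aromatic carbon. Within the data shown here, no measured step bears on this change; the only measured step concerns a different site of the shared core and is itself unreadable. With every shown value sitting at the limit, the expectation for compound 4 in this assay rests on the series as a whole, which shows no potency anywhere. Compound 4 is therefore expected to give 200000 nM, with a range of 60000 nM to 700000 nM, most likely reported as a limit again. The step this estimate means, a step that the limit leaves unreadable from compound 3 to compound 4, is expected to be no change beyond the scatter.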

Compound 4, half-maximal inhibitory concentration: > 150000 nM
Compound 4 gave a limit, no number; the forecaster's own chance of this, stated with the estimate: 85%; the middle value is on the limit's open side.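

No step can be read between compound 3 and compound 4, as both stand only as limits, not numbers: the limit of > 150000 nM in this assay, at which 4 of the 4 values shown sit.

The compounds shown leave open what 4-methoxyphenyl in place of naphthalen-2-yl does, and whether any analogue on the shared core gives a numerical value in this assay.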